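The source may report more compounds than this note shows. Statements on the series, on what has been measured and on what is new or still open speak of the compounds shown alone.

Working notes on the series built on the shared core of compound 1 `O=C(CN1CCN(c2ccccc2)CC1)N1CCN(c2nnc(-c3ccc(Cl)cc3)c(-c3ccc(Cl)cc3)n2)CC1`, the members differing only in the aryl group on the amine nitrogen in a ring. In an ADME assay on NIH3T3 cells (Mus musculus) for cytotoxicity, read by MTT assay, with a stated time of 24 h (on this read-out higher numbers stand for weaker inhibition and lower numbers for stronger inhibition), compound 1 returns only a limit, > 850000 nM. Compound 2 `O=C(CN1CCN(c2ccccc2Cl)CC1)N1CCN(c2nnc(-c3ccc(Cl)cc3)c(-c3ccc(Cl)cc3)n2)CC1` in this assay likewise returns a limit, > 803000 nM. Compound 3 `O=C(CN1CCN(c2cccc(Cl)c2)CC1)N1CCN(c2nnc(-c3ccc(Cl)cc3)c(-c3ccc(Cl)cc3)n2)CC1` in this assay also gives a limit, > 803000 nM. Compound 3 therefore stands with the other two at the ceiling of the read-out, and the steps a step that the two limits leave unreadable from compound 1 to compound 2, a step that the two limits leave unreadable from compound 1 to compound 3 and a step that the two limits leave unreadable from compound 2 to compound 3 cannot be sized because the limit of > 803000 nM in this assay, at which 2 of the 3 values shown sit, and the limit of > 850000 nM in this assay, at which 1 of the 3 values shown sits, bound every value shown. Compound 4 `O=C(CN1CCN(c2ccc([N+](=O)[O-])cc2)CC1)N1CCN(c2nnc(-c3ccc(Cl)cc3)c(-c3ccc(Cl)cc3)n2)CC1` carries the change (4-nitrophenyl in place of 3-chlorophenyl on an amine nitrogen in a ring). Going by the values given here, none of the measured steps offers a readable size or direction that bears on this change. The expected step that the limit leaves unreadable from compound 3 to compound 4 is therefore no step beyond the scatter, with the measurement most likely returning a limit once more. Compound 4 is estimated at 850000 nM in this assay, within a range of 400000 nM to 2000000 nM.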

Compound 4, half-maximal inhibitory concentration: > 789000 nM
Compound 4: only a limit was reported; the forecaster's own chance of this, stated with the estimate: 85%; the middle value does not contradict the limit.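

In this assay compound 4 returns only a limit, > 789000 nM. Going by these compounds alone, no step from compound 1, compound 2 or compound 3 to compound 4 can be read. The compounds shown leave open whether any aryl group on the amine nitrogen in a ring changes the read-out in this assay.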